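Swapping an Ether Chain for a Fluorinated Ring

The source may hold more compounds than are shown below. What is called first, only, known or untested is meant among the compounds shown, and "the series" means these compounds.

Of the compounds shown here, three have so far been measured in an ADME assay on RAW264.7 cells (Mus musculus) for cytotoxicity, read by MTT assay, with a stated time of 24 h, in the presence of a further agent that is not named here; a higher number here means a weaker inhibitor, a lower number a stronger inhibitor. Compound 1 `O=C1OC(Cc2nc(Cc3ccccc3)no2)c2ccccc21` is built on a different frame from the other two. In this assay compound 1 gives > 40000 nM, which is a limit of the assay rather than a number. Compound 2 `COc1cc(OC)c2c(c1)C(C(O)c1ccc(O)cc1)OC2=O` carries a hydrogen on an oxygen on an aromatic ring. In this assay compound 2 gives > 40000 nM, again only a limit. Compound 3 `CCOCCOc1ccc(C(O)C2OC(=O)c3c(OC)cc(OC)cc32)cc1` carries a 2-ethoxyethyl in that place instead. In this assay compound 3 gives > 40000 nM, also a limit. Compound 3 thus stands exactly where every measured compound stands, since (the limit of > 40000 nM in this assay, at which 3 of the 3 values shown sit). Among the measured compounds shown here, the only step between measured compounds, a step that the two limits leave unreadable from compound 2 to compound 3, gives no readable size because both of its ends are limits.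

Compound 4 `COc1cc(OC)c2c(c1)C(C(O)c1ccc(OCc3ccc(OC(F)(F)F)cc3)cc1)OC2=O` differs from compound 3 in one place: 4-(trifluoromethoxy)phenyl in place of ethoxymethyl on a saturated chain carbon bound to an oxygen on an aromatic ring. For the measured compounds named here, no measured step bears directly on this change, and the one step available is unreadable. Compound 4 is therefore expected to sit at the same limit, with the expected step of a number no higher from compound 3 to compound 4 (the limit leaves the size open) being none beyond the scatter. The estimate for compound 4 is 40000 nM, with a range from 20000 nM to 80000 nM.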

Compound 4, half-maximal inhibitory concentration: > 40000 nM
Compound 4 was reported as a limit; the forecaster's own chance of this, stated with the estimate: 85%; the middle value sits exactly at the limit.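

Compound 4 gives > 40000 nM in this assay, again a limit of the assay and not a number. The step between compound 3 and compound 4 therefore cannot be read, as both of its ends are limits: the limit of > 40000 nM in this assay, at which 4 of the 4 values shown sit. The compounds shown leave open whether changing the group on that oxygen alters the value in this assay at all.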